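Swapping the Benzoyl Group for a Cyano Group

The source may report more compounds than this note shows. Statements on the series, on what has been measured and on what is new or still open speak of the compounds shown alone.

Compound 1 `CC(=O)/C(=C\c1c(-c2ccccc2)[nH]c2ccccc12)S(=O)(=O)c1ccccc1`: 3700 nM
Compound 2 `O=C(/C(=C\c1c(-c2ccccc2)[nH]c2ccccc12)S(=O)(=O)c1ccccc1)c1ccccc1`: 6600 nM

Compound 2 stands at 6600 nM in a functional assay on OVCAR-4 cells (Homo sapiens) for inhibition, read by sulforhodamine B assay, with a stated time of 48 h (on this read-out higher numbers stand for weaker inhibition of growth and lower numbers for stronger inhibition of growth), and compound 1 at 3700 nM, the gap between them within the scatter. Compound 3 `N#C/C(=C\c1c(-c2ccccc2)[nH]c2ccccc12)S(=O)(=O)c1ccccc1` differs from compound 2 by cyano in place of benzoyl on a double-bonded chain carbon bound to a double-bonded chain carbon and a sulfonyl sulfur. Among the compounds with values here, the only measured step that touches this position, a 1.8-fold higher number from compound 1 to compound 2 (0.25 log units; within the scatter), barely moved the number, so no step beyond the scatter is expected here; the expected step is a 1.3-fold lower number from compound 2 to compound 3 (0.12 log units; within the scatter). Compound 3 is therefore estimated at 5000 nM, within a range from 1500 nM to 16000 nM.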

Compound 3, concentration for 50% growth inhibition: 5500 nM
For compound 3 the middle estimate is 1.1-fold (0.04 log units) below the measured one; measured number inside the range.
By their numbers in this assay, from the lowest: compounds 1, 3 and 2 (each within the scatter of the next).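

In this assay, cyano in place of benzoyl on this double-bonded chain carbon gives a 1.2-fold lower number from compound 2 to compound 3 (0.08 log units; within the scatter), and cyano in place of acetyl gives a 1.5-fold higher number from compound 1 to compound 3 (0.17 log units; within the scatter). The position has now carried three groups, including benzoyl with 8 heavy atoms and cyano with 2, and all three compounds lie within the scatter of one another. No evidence is available to explain this result. On these data alone, whether an amine or a carboxylic acid on this carbon would leave the number in the same place remains open, as does the effect of changes elsewhere on the shared core.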